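From compound 1 to compound 3: adding methoxy

The source may report more compounds than this note shows. Statements on the series, on what has been measured and on what is new or still open speak of the compounds shown alone.

Measured in an ADME assay on Vero cells (Chlorocebus sabaeus) for cytotoxicity, with a stated time of 72 h; a higher number here means a weaker inhibitor, a lower number a stronger inhibitor:
Compound 1 `CCOC(=O)c1cc(/C=C/c2ccnc3ccccc23)on1` gives > 128000 nM (a limit)
Compound 2 `CCOC(=O)c1cc(/C=C/c2ccc3ncccc3c2)on1` gives > 128000 nM (a limit)

Compound 1 stands at > 128000 nM (a limit, not a number) in this assay. Taken together, the two compounds show the limit of > 128000 nM in this assay, at which 2 of the 2 values shown sit (no number for either).

Compound 3 `CCOC(=O)c1cc(/C=C/c2ccnc3ccc(OC)cc23)on1` carries methoxy in place of hydrogen on an aromatic carbon (a six-membered aromatic ring of carbon only, part of a fused or bridged system of two rings). Going by the values given here, no step between measured compounds gives a size for a change of this kind. No step beyond the usual scatter is expected in this assay, and a reading of compound 3 at the same limit is the likeliest outcome. This expectation rests on compound 1 at > 128000 nM (a limit). The step expected is an at least 1.1-fold lower number from compound 1 to compound 3 (0.04 log units; that floor lies within the scatter) (an estimate only). For compound 3 the estimated value is 115000 nM (expected range 45000 nM to 128000 nM) in these notes.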

Compound 3, half-maximal inhibitory concentration: > 128000 nM
Compound 3 gave a limit, no number; the forecaster's own chance of this, stated with the estimate: 70%; middle value at least 1.1-fold (0.04 log units) away from the limit.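

Compound 1 and compound 3 both read as limits, not numbers, in this assay, so no step can be read for methoxy in place of hydrogen on an aromatic carbon. All three compounds sit together: the limit of > 128000 nM in this assay, at which 3 of the 3 values shown sit. The compounds shown leave open whether methoxy in place of hydrogen changes the reading in this assay at all.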